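Replacing the Basic Side Chain with an Oxygen-Rich Group

The source may hold more compounds than are shown below. What is called first, only, known or untested is meant among the compounds shown, and "the series" means these compounds.

Compound 2 `CCN(CC)CCNC(=O)c1ccc(C(CC)(CC)c2ccc(OCCC(O)(CC)CC)c(C)c2)n1CC` carries a (2-(diethylamino)ethyl)amino group on the carbonyl carbon of the shared core. In a functional assay on HepG2 cells (Homo sapiens) for antiproliferative activity, read by MTT assay, with a stated time of 48 h (a higher number here means a weaker inhibitor, a lower number a stronger inhibitor), compound 2 gives 230 nM, the lowest of the three numbers. Compound 1 `CCn1c(C(=O)NCCN(C)C)ccc1C(CC)(CC)c1ccc(OCCC(O)(CC)CC)c(C)c1`, which differs only by dimethylamino in place of diethylamino, gives 240 nM in this assay; the step of a 1.0-fold lower number from compound 1 to compound 2 (0.02 log units; within the scatter) lies within the scatter, so the two stand level. Compound 3 `CCOC(=O)CN(C)C(=O)c1ccc(C(CC)(CC)c2ccc(OCCC(O)(CC)CC)c(C)c2)n1CC`, with ((ethoxycarbonyl)methyl)(methyl)amino on the carbonyl carbon, gives 25300 nM; the steps of a 110-fold higher number from compound 2 to compound 3 (2.04 log units; beyond the scatter) and a 110-fold higher number from compound 1 to compound 3 (2.02 log units; beyond the scatter) are large and beyond the scatter.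

Compound 4 `CCOC(=O)C(CC(=O)OC)NC(=O)c1ccc(C(CC)(CC)c2ccc(OCCC(O)(CC)CC)c(C)c2)n1CC` takes the change (a group of 11 heavy atoms (7 carbon, 4 oxygen; no ring) in place of a group of 7 heavy atoms (6 carbon, 1 nitrogen; no ring), on an amide-type nitrogen). This resembles the move to compound 3: the basic amine chain leaves and a group rich in oxygen, with no nitrogen, enters on the amide-type nitrogen. The steps to compound 3 are the only ones that bear on it, and both were large upward. A step of similar size in this assay is therefore expected, toward a weaker inhibitor, with the expected step being an 87-fold higher number from compound 2 to compound 4 (1.94 log units; beyond the scatter). Compound 4 is accordingly expected to give 20000 nM, with a range from 5000 nM to 60000 nM.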

Compound 4, half-maximal inhibitory concentration: > 50000 nM
Compound 4 was reported as a limit (the forecaster's own chance of this, stated with the estimate: 15%); middle value at least 2.5-fold (0.39 log units) from the limit.
By their numbers in this assay, from the lowest: compounds 2 and 1 (each within the scatter of the next); then compound 3. At a limit, above all of these: compound 4.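

Compound 4 keeps the amide hydrogen that compound 1 and compound 2 also carry, yet it still falls far behind both in this assay, with an at least 210-fold higher number from compound 2 to compound 4 (2.33 log units; beyond the scatter) and an at least 200-fold higher number from compound 1 to compound 4 (2.31 log units; beyond the scatter). The large loss seen with compound 3 therefore does not require a methyl group on the amide-type nitrogen, as compound 3 alone had left possible: across these compounds, both groups that lack the amine nitrogen and carry ester groups stand far above the two basic side chains. Compound 4 is the only compound shown that reaches a limit, so its true value is unknown: the limit of > 50000 nM in this assay, at which 1 of the 4 values shown sits.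

Compound 3 and compound 4 cannot be ranked against each other, as an at least 1.9-fold higher number from compound 3 to compound 4 (0.29 log units; that floor lies within the scatter) gives only a floor within the scatter. On these data alone, whether the loss follows from losing the amine or from gaining the esters stays open, and a 2-hydroxyethyl chain or a carboxylic acid on the same amide-type nitrogen, or a pyrrolidine at the end of the chain, would begin to separate these readings.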